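Rearranging the branched alkyl group on a cyanoguanidine

A few compounds are considered here, and "the series" means these few. Any claim that something is new, unique, unknown or untested is made for them only; others in the source may bear on it.

Compound 1, `N#CN/C(=N\C1CCCC1)Nc1cccnc1`, gives 20 mg/kg in a functional assay on the whole organism (blood, strain Wistar-Okamoto) with Rattus norvegicus as the target, with a stated time of 5 days; a higher number here means that more compound is needed for the effect, a lower number that less compound is needed.
Compound 2, `CCC(CC)/N=C(\NC#N)Nc1ccncc1`, gives 2.5 mg/kg in this assay.

Of the two measured compounds, compound 2 has the lower number in this assay, meaning less of it is needed for the effect; the number for compound 1 lies well above it, beyond the usual scatter. Compound 1 differs from compound 2 in more than one place, so the two values show only that, and no single structural cause can be read from them.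

Compound 3, `CCC(C)(C)/N=C(\NC#N)Nc1ccncc1`, is the next compound to be measured. It differs from compound 2 in one place: 1,1-dimethylpropyl in place of pentan-3-yl on a double-bonded nitrogen. The atoms are the same and only their joining changes, so no new donor, acceptor or charge is introduced. For the measured compounds named here, no measured pair here tells how such a rearrangement shifts the read-out, so the expectation rests on the modest nature of the change alone.

Compound 3 is therefore expected to stay close to compound 2, with a step of a 1.2-fold higher number from compound 2 to compound 3 (0.08 log units; within the scatter), giving an estimated 3 mg/kg, likely between 1.2 mg/kg and 8 mg/kg.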

Compound 3, minimum effective dose: 2.5 mg/kg
Beside the measured number, compound 3's estimate is 1.2-fold (0.08 log units) above it, within the range that was stated.
By their numbers in this assay, from the lowest: compounds 2 and 3 (each within the scatter of the next); then compound 1.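

Swapping pentan-3-yl for 1,1-dimethylpropyl on the double-bonded nitrogen gives no change at the digits printed from compound 2 to compound 3 (within the scatter) in this assay. For the compounds shown here, this is the first comparison here in which only one place differs, and it shows that, for this pair, the way these five carbons are joined leaves no mark on the minimum effective dose beyond the usual variation between repeat measurements. Nothing measured here accounts for this result.

Both groups are built from the same atoms, so this pair cannot show what would happen with a different group on that nitrogen, such as a plain methyl, a longer chain like n-octyl, or a chain ending in an amine or a carboxylic acid. A single pair also cannot show whether the same rearrangement would leave the dose unchanged on a different core, such as the core of compound 1, so the result should be read as a statement about this one change on the core shared by compound 2 and compound 3.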